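Ortho-methyl on the hydrazone phenyl of a methylated aniline

A few compounds are considered here, and "the series" means these few. Any claim that something is new, unique, unknown or untested is made for them only; others in the source may bear on it.

Compound 1 `CC(=O)/C(=N\Nc1ccccc1)Nc1cccc(Cl)c1`: 2720 nM; 2720 nM (2 entries)
Compound 2 `CC(=O)/C(=N\Nc1ccccc1)N(C)c1cccc(Cl)c1`: > 10000 nM
Compound 3 `CC(=O)/C(=N\Nc1ccccc1Cl)Nc1cccc(Cl)c1`: 417 nM; 417 nM (2 entries)

In an assay on isolated protein for binding affinity to corticotropin-releasing factor receptor 1 (Homo sapiens) (a higher number here means a weaker inhibitor, a lower number a stronger inhibitor), compound 1 gives 2720 nM; 2720 nM (2 entries) and compound 3 gives 417 nM; 417 nM (2 entries). For compound 2 this assay reports only a limit, > 10000 nM; this is one of the values that sit at the limit of > 10000 nM in this assay, at which 1 of the 3 values shown sits, and it is the weakest of the three shown. Compound 4 `CC(=O)/C(=N\Nc1ccccc1C)N(C)c1cccc(Cl)c1` keeps the methylated aniline of compound 2 and differs by methyl in place of hydrogen on an aromatic carbon. Among the measured compounds shown here, no measured pair shows this exact step, so its size is open; a shift toward stronger binding is possible, but compound 2 gives no number to measure it from. For compound 4 the estimate is 8000 nM, between 2000 nM and 30000 nM, meaning an expected step of an at least 1.2-fold lower number from compound 2 to compound 4 (0.09 log units; that floor lies within the scatter).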

Compound 4, inhibition constant: > 10000 nM
Compound 4: a limit, no number; the forecaster's own chance of this, stated with the estimate: 55%; middle value at least 1.2-fold (0.09 log units) from the limit.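

Compound 2 and compound 4 are both reported only as limits, so no step between them can be read: the limit of > 10000 nM in this assay, at which 2 of the 4 values shown sit.

Going by these compounds, whether methyl in place of hydrogen on an aromatic carbon changes the result in this assay at all stays open.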